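Methyl added to a para-alkyl group on a sulfonamide

The source may hold more compounds than are shown below. What is called first, only, known or untested is meant among the compounds shown, and "the series" means these compounds.

Four compounds share a common amine core and differ in the aryl fragment attached to the cyclohexyl amine. Compound 1 `CCCN(CC[C@H]1CC[C@H](NC(=O)c2ccc(-c3noc(CC)n3)cc2)CC1)[C@H]1CCc2nc(N)sc2C1` and compound 2 `CCCN(CC[C@H]1CC[C@H](NC(=O)c2ccc(-c3noc(C(C)C)n3)cc2)CC1)[C@H]1CCc2nc(N)sc2C1` are amides; compound 3 `CCCN(CC[C@H]1CC[C@H](NS(=O)(=O)c2ccc(C(C)C)cc2)CC1)[C@H]1CCc2nc(N)sc2C1` and the as yet unmeasured compound 4 `CCCN(CC[C@H]1CC[C@H](NS(=O)(=O)c2ccc(C(C)(C)C)cc2)CC1)[C@H]1CCc2nc(N)sc2C1` are sulfonamides. How the core of compound 3 differs from that of compound 1 is not broken down here.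

In an assay on brain for displacement of a labelled ligand from D(3) dopamine receptor (Rattus norvegicus) (on this read-out higher numbers stand for weaker inhibition and lower numbers for stronger inhibition), compound 1 gives 2.1 nM, and compound 2 gives 2 nM. The change from compound 1 to compound 2 is methyl in place of hydrogen on a saturated chain carbon bound to an aromatic carbon and a saturated chain carbon and produced a 1.1-fold lower number from compound 1 to compound 2 (0.02 log units; within the scatter). Compound 3 gives 4.5 nM in this assay, the highest of the three numbers.

The change planned for compound 4 is methyl in place of hydrogen on a saturated chain carbon bound to an aromatic carbon and two saturated chain carbons. It is the same kind of change as that from compound 1 to compound 2, but not the same: in the earlier pair the altered carbon is bound to an aromatic carbon and a saturated chain carbon, whereas here it is bound to an aromatic carbon and two saturated chain carbons. Since the earlier addition of a methyl left the number essentially unchanged, compound 4 is expected to sit close to compound 3, with an estimated step of no change at the digits printed from compound 3 to compound 4 (within the scatter). Compound 4 is therefore estimated at 4.5 nM in this assay, with a likely range from 2 nM to 10 nM.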

Compound 4, inhibition constant: 5 nM
For compound 4 the middle estimate is 1.1-fold (0.05 log units) below the measured one, and the stated range covers the measured number.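

In this assay, the methyl that turns the isopropyl of compound 3 into the tert-butyl of compound 4 gives a 1.1-fold higher number from compound 3 to compound 4 (0.05 log units; within the scatter), so the two compounds cannot be told apart on this read-out. Set beside the earlier methyl addition, which turned ethyl into isopropyl on the oxadiazole-bearing amide, the step carries over from one core to the other as a change with no effect that can be read, and the two steps do not differ: the same change on two cores in this assay, a 1.1-fold lower number (0.02 log units; within the scatter) from compound 1 to compound 2 and a 1.1-fold higher number (0.05 log units; within the scatter) from compound 3 to compound 4, 1.2-fold (0.07 log units) apart, within the scatter of two such steps This rests on only two pairs and shows agreement only in the absence of a readable effect; it does not show that the methyl would leave the number unchanged on any other core, and the two pairs are not strictly alike, since the carbon carrying the methyl in compound 4 is bound to an aromatic carbon and two saturated chain carbons, while in the earlier pair it is bound to an aromatic carbon and a saturated chain carbon.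

The compounds shown leave open how a longer chain, a cyclopropyl ring or a carboxylic acid at this place would read in this assay. They also leave open whether the methyl step would look the same on any other read-out.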